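Swapping an Acid Side Chain for a Branched Alkyl

The source may report more compounds than this note shows. Statements on the series, on what has been measured and on what is new or still open speak of the compounds shown alone.

Of the compounds shown here, three have been tested in a functional assay on the whole organism (Tail, strain ICR) with Mus musculus as the target, in the tail flick test, with a stated time of 150 min, at a dose of 25 umol/kg by the oral route; a lower number here means a weaker effect, a higher number a stronger effect of the compound at the dose given. Compound 1 `O=C(O)[C@@H]1CCCN1C(=O)CN(c1nc(Cl)nc2[nH]cnc12)C1CC1` gives 7.29%. Compound 2 `O=C(O)C[C@H](NC(=O)CN(c1nc(Cl)nc2[nH]cnc12)C1CC1)C(=O)O` gives 11.6%. Compound 3 `O=C(OCc1ccccc1)[C@@H]1CCCN1C(=O)CN(c1ncnc2c1ncn2C1CCCCO1)C1CC1` gives 7.85%. All three numbers are low, and the gaps between compound 2 and each of the other two lie within the usual scatter of this kind of measurement, so no real difference among them can be claimed from these data.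

Compound 4 `CC[C@H](C)[C@H](NC(=O)CN(c1nc(Cl)nc2[nH]cnc12)C1CC1)C(=O)O` has not yet been measured. It differs from compound 2 in one place: sec-butyl in place of carboxymethyl on a saturated chain carbon bound to an amide-type nitrogen and a carbonyl carbon. Among the measured compounds shown here, nothing measured so far isolates this kind of change, so there is no recorded step to lean on. Since every compound tested gives a small read-out in this assay, the expectation for compound 4 is a number in the same low region, with a step from compound 2 of a number 1.6 percentage points lower from compound 2 to compound 4 (within the scatter) that is not expected to exceed the scatter in either direction. Compound 4 is accordingly estimated at 10%, with a plausible range from 2% to 22%.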

Compound 4, a percentage reported as activity, at one dose (the size of the read-out at that dose, not a potency): 6.71%
Estimate against measurement, compound 4: 3.3 percentage points above; the range from low to high includes it.
By their numbers in this assay, from the lowest: compounds 4, 1, 3 and 2 (each within the scatter of the next).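

Among the compounds shown here, this is the first step that isolates a single change at this position: in this assay, sec-butyl in place of carboxymethyl on a saturated chain carbon bound to an amide-type nitrogen and a carbonyl carbon gives a number 4.9 percentage points lower from compound 2 to compound 4 (within the scatter). An all-carbon group of the same heavy-atom count can therefore take the place of carboxymethyl here with no difference that can be claimed, although this rests on one pair of compounds. Nothing in the data gives a reason for this result.

Going by these compounds, it remains open whether an amine, a hydroxymethyl or a longer chain at this place would give a step beyond the scatter. The read-out also comes from a single dose, so it leaves open how compound 2 and compound 4 would compare at other doses.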